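A pyridin-3-yl swap on the shared core

This account rests on a few compounds, and the source may have more. Where it says the series, first, only, none or still open, it means among the compounds named here.

In an ADME assay on L02 cells (Homo sapiens) for antiproliferative activity, read by CCK-8 assay, with a stated time of 6 days (a lower number here means a stronger inhibitor, a higher number a weaker inhibitor), compound 3 `CCN(c1ccc(C#N)c(Cl)c1)c1cc(-c2cn[nH]c2)ccc1C` offers no number to start from, as its result reads "not determined" (no result reported). Moving to compound 4 `CCN(c1ccc(C#N)c(Cl)c1)c1cc(-c2cccnc2)ccc1C` puts pyridin-3-yl in place of 1H-pyrazol-4-yl on an aromatic carbon. Among the compounds with values here, one measured step bears on this carbon. Compound 1 `CCN(c1ccc(C#N)c(Cl)c1)c1cc(-c2ccccc2)ccc1C` gives > 30000 nM, which is a limit of the assay. Compound 2 `CCN(c1ccc(C#N)c(Cl)c1)c1cc(-c2ccnn2C)ccc1C` gives 6230 nM. Placing 1-methyl-1H-pyrazol-5-yl where phenyl stood gives an at least 4.8-fold lower number from compound 1 to compound 2 (0.68 log units; beyond the scatter), so changing this group can move the number beyond the scatter. With no number for compound 3, no size or direction of step can be expected from it. The estimate therefore leans on compound 2 at 6230 nM, on its weaker side. Compound 4 is expected near 12000 nM, with an estimated range of 4000 nM to 30000 nM.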

Compound 4, half-maximal inhibitory concentration: 12700 nM
Compound 4: the middle estimate sits 1.1-fold (0.02 log units) below what was measured; measured number inside the range.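

In this assay, pyridin-3-yl in place of phenyl gives an at least 2.3-fold lower number from compound 1 to compound 4 (0.37 log units; beyond the scatter), so a five-membered ring is not needed to lower the number at this carbon. The ring type still matters, since pyridin-3-yl in place of 1-methyl-1H-pyrazol-5-yl gives a 2.0-fold higher number from compound 2 to compound 4 (0.31 log units; beyond the scatter). From the compounds shown here alone, compound 1 carries a limit and not a number, so the true size of its step stays unknown: the limit of > 30000 nM in this assay, at which 1 of the 4 values shown sits.

The step from compound 3 cannot be read. Going by these compounds, how an amine or a carboxylic acid on the pyridin-3-yl ring would move the number remains open.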